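Methyl for Fluoro on the Phenoxy Ring of Compound 3

The source may report more compounds than this note shows. Statements on the series, on what has been measured and on what is new or still open speak of the compounds shown alone.

Compound 1 `NC1=NC2(CCOCC2)N(OCCCOc2cccc(Cl)c2)C(N)=N1`: 520 nM
Compound 2 `NC1=NC2(CCOCC2)N(OCCCOc2ccc(Cl)c(Cl)c2)C(N)=N1`: 1240 nM
Compound 3 `NC1=NC2(CCOCC2)N(OCCCOc2ccc(F)cc2)C(N)=N1`: 2380 nM

Of the compounds shown here, three sharing one core have been measured in a functional assay on HL-60 cells (Homo sapiens) for antiproliferative activity, read by MTT assay, with a stated time of 72 h; on this read-out higher numbers stand for weaker inhibition and lower numbers for stronger inhibition. Compound 1 gives 520 nM, compound 2 gives 1240 nM and compound 3 gives 2380 nM. Compound 3 therefore carries the highest number of the three: one of the two steps reaching it is a 1.9-fold higher number from compound 2 to compound 3 (0.28 log units; within the scatter), while the other is a 4.6-fold higher number from compound 1 to compound 3 (0.66 log units; beyond the scatter). Between the first two compounds the step is a 2.4-fold higher number from compound 1 to compound 2 (0.38 log units; beyond the scatter).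

Compound 4 `Cc1ccc(OCCCON2C(N)=NC(N)=NC23CCOCC3)cc1` is not yet measured in this assay. It differs from compound 3 by methyl in place of fluoro on an aromatic carbon. Within the data shown here, none of the measured steps swaps one substituent on that aromatic carbon for another of this kind; the closest precedent is the step of a 2.4-fold higher number from compound 1 to compound 2 (0.38 log units; beyond the scatter), a single substituent added on an aromatic carbon of the same ring, and the two steps toward compound 3 lie between within the scatter and a modest size. Nothing in the data points to a large move in either direction. The expectation is thus a step of a 1.2-fold lower number from compound 3 to compound 4 (0.08 log units; within the scatter), with compound 4 estimated at 2000 nM, between 800 nM and 5000 nM.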

Compound 4, half-maximal inhibitory concentration: 2580 nM
Compound 4: middle estimate off by 1.3-fold (0.11 log units), on the low side; the measured number falls inside the stated range.
By their numbers in this assay, from the lowest: compound 1; then compounds 2, 3 and 4 (each within the scatter of the next, the first and the last beyond it).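

In this assay, among these compounds, methyl in place of fluoro on this aromatic carbon, para to a large group, gives a 1.1-fold higher number from compound 3 to compound 4 (0.04 log units; within the scatter) and so stays within the usual scatter; this is the first direct swap of one substituent for another at this place, and the read-out does not tell the two groups apart. The 4-methylphenyl compound also stands clear of both chlorinated compounds, with a 2.1-fold higher number from compound 2 to compound 4 (0.32 log units; beyond the scatter) and a 5.0-fold higher number from compound 1 to compound 4 (0.70 log units; beyond the scatter) both modest in size, whereas compound 3 stayed within the scatter of compound 2. No measurement available here explains why fluoro and methyl read alike at this place or why the chlorinated compounds lie apart from compound 4.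

The compounds shown leave open how methoxy, trifluoromethyl, a nitrile or an amine would read on this same aromatic carbon. They also leave open whether methyl in place of fluoro would stay as quiet with a longer chain joining the phenoxy group to the shared core.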